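A few compounds are considered here, and "the series" means these few. Any claim that something is new, unique, unknown or untested is made for them only; others in the source may bear on it.

Compound 1 `CCN(CC)C(=O)c1ccccc1OCC1=NCCN1`: in a functional assay for activation of Alpha-1B adrenergic receptor (Homo sapiens), read by calcium flux (on this read-out lower numbers stand for an effect already at smaller amounts and higher numbers for an effect only at larger amounts of compound), compound 1 gives < 5020 nM, which is a limit of the assay and not a measured number.
Compound 2 `Cc1cccnc1-c1ccccc1OCC1=NCCN1`: in this assay compound 2 gives < 100000 nM, again a limit rather than a number.
Compound 3 `c1cnc(-c2ccccc2OCC2=NCCN2)nc1`: in this assay compound 3 gives < 100000 nM, also a limit.

None of the three compounds has a measured number, so none can be called stronger or weaker than another. Compound 3 stands at the limit of < 100000 nM in this assay, at which 2 of the 3 values shown sit. Compound 1 stands at the limit of < 5020 nM in this assay, at which 1 of the 3 values shown sits. Among the compounds with values here, nothing more can be read about where compound 3 stands, and no step between two measured compounds exists to lean on.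

Compound 4 `c1coc(-c2ccccc2OCC2=NCCN2)c1` is the next compound; it differs from compound 3 in one place: furan-2-yl in place of pyrimidin-2-yl on an aromatic carbon. Within the data shown here, because no step between measured compounds is known, neither a direction nor a size can be taken from the data; the step from compound 3 to compound 4 is expected to stay within the usual scatter of the assay, as a step that the limit leaves unreadable from compound 3 to compound 4 expresses. The value expected for compound 4 in this assay is 8000 nM, with a range from 1000 nM to 60000 nM, and there is a fair chance that only a limit will again be reported.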

Compound 4, half-maximal effective concentration: 10 nM
For compound 4 the middle estimate is 800-fold (2.90 log units) above the measured one, outside the stated range (below it).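

Compound 3 carries only a limit, so the change to furan-2-yl in compound 4 gives no step of readable size: the limit of < 100000 nM in this assay, at which 2 of the 4 values shown sit.

The compounds shown leave open how large the effect of replacing pyrimidin-2-yl with furan-2-yl really is, and they include no pair differing in one place with a measured number on both sides.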